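This account rests on a few compounds, and the source may have more. Where it says the series, first, only, none or still open, it means among the compounds named here.

The measured compounds, with their numbers in an assay on HEK293-TREx cells for antagonist activity at transient receptor potential cation channel subfamily A member 1 (Homo sapiens), read by calcium flux; on this read-out lower numbers stand for stronger inhibition and higher numbers for weaker inhibition:
Compound 1 `O=C(Nc1cc(NCc2cccs2)cc(C(F)(F)F)c1)c1cccs1` gives 2700 nM.
Compound 2 `CCCN(CCC)c1cc(NC(=O)c2cccs2)cc(C(F)(F)F)c1` reaches only the assay limit > 32000 nM (the limit of > 32000 nM in this assay, at which 1 of the 3 values shown sits).
Compound 3 `CCCNc1cc(NC(=O)c2cccs2)cc(C(F)(F)F)c1` gives 390 nM.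

Compound 3 thus holds the lowest of the two actual numbers, with compound 1 nearest: a 6.9-fold lower number from compound 1 to compound 3 (0.84 log units; beyond the scatter). The steps of an at least 11-fold higher number from compound 1 to compound 2 (1.07 log units; beyond the scatter) and an at least 82-fold lower number from compound 2 to compound 3 (1.91 log units; beyond the scatter) both concern the nitrogen on the aromatic ring. Compound 4 `CCCNc1cc(NC(=O)c2ccccn2)cc(C(F)(F)F)c1` differs from compound 3 elsewhere: pyridin-2-yl in place of thiophen-2-yl on a carbonyl carbon. Among the compounds with values here, none of the measured steps touch the carbonyl side, so they give no direct guide to the size or direction of this change. The expected step for compound 4 is a 1.5-fold higher number from compound 3 to compound 4 (0.19 log units; within the scatter), likely within the scatter. Compound 4 is therefore estimated at 600 nM, between 150 nM and 2500 nM.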

Compound 4, half-maximal inhibitory concentration: > 32000 nM
Compound 4 ended at the assay's limit; the forecaster's own chance of this, stated with the estimate: 5%; middle value at least 53-fold (1.72 log units) from the limit.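

On the carbonyl carbon, pyridin-2-yl in place of thiophen-2-yl gives an at least 82-fold higher number from compound 3 to compound 4 (1.91 log units; beyond the scatter), so the carbonyl side proves at least as sensitive in this series as the nitrogen on the aromatic ring. Two aromatic rings with one hetero atom each are thus far from interchangeable at this place, even with the same count of hydrogen-bond acceptors. The result for compound 4 is a limit of the assay and not a number: the limit of > 32000 nM in this assay, at which 2 of the 4 values shown sit.

Going by these compounds, it remains open whether a phenyl or furan-2-yl group on the carbonyl carbon would behave like thiophen-2-yl or like pyridin-2-yl. On these data alone, it is equally open whether pyridin-3-yl or pyridin-4-yl would share the fate of pyridin-2-yl.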